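The source may report more compounds than this note shows. Statements on the series, on what has been measured and on what is new or still open speak of the compounds shown alone.

The measured compounds:
compound 1 `CCN(CC)S(=O)(=O)c1ccc(S(=O)(=O)N2CCC[C@@H](C(=O)NC3COC3)C2)cc1`; in a functional assay on BXPC-3 cells (Homo sapiens) for inhibition, read by MTT assay, with a stated time of 7 days (on this read-out higher numbers stand for weaker inhibition and lower numbers for stronger inhibition), compound 1 gives 13800 nM
compound 2 `CCN(CC)S(=O)(=O)c1ccc(S(=O)(=O)N2CCC[C@@H](C(=O)NC3CN(S(C)(=O)=O)C3)C2)cc1`; in this assay compound 2 gives 7400 nM

On the numbers shown, compound 2 sits at the lower end of the two, yet the step of a 1.9-fold lower number from compound 1 to compound 2 (0.27 log units; within the scatter) lies within the scatter, so the two compounds are not separated. The unmeasured compound 3 `CCN(CC)S(=O)(=O)c1ccc(S(=O)(=O)N2CCC[C@@H](c3cc(C)no3)C2)cc1` differs from compound 2 in one place: 3-methyl-1,2-oxazol-5-yl in place of (1-(methylsulfonyl)azetidin-3-yl)carbamoyl on a saturated ring carbon. Among the measured compounds shown here, the single measured step exchanged the ring on the amide-type nitrogen while the carbamoyl link remained; the change to compound 3 removes that link entirely, so no measured step bears on it directly, and the one step that exists was small. With nothing to lean on, compound 3 is expected to land near the value of compound 2, 7400 nM, with wide uncertainty, an expected step of a 1.4-fold higher number from compound 2 to compound 3 (0.13 log units; within the scatter) in this assay. The estimate for compound 3 is 10000 nM, with a range from 2000 nM to 50000 nM.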

Compound 3, half-maximal inhibitory concentration: 7700 nM
Beside the measured number, compound 3's estimate is 1.3-fold (0.11 log units) above it; the range from low to high includes it.
By their numbers in this assay, from the lowest: compounds 2, 3 and 1 (each within the scatter of the next).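

In this assay, the carbamoyl link on the saturated ring carbon can be replaced outright, amide hydrogen included, without separating the compounds: the exchange for 3-methyl-1,2-oxazol-5-yl gives a 1.0-fold higher number from compound 2 to compound 3 (0.02 log units; within the scatter), and set against the oxetane amide it gives a 1.8-fold lower number from compound 1 to compound 3 (0.25 log units; within the scatter). This position therefore accepts a five-membered aromatic ring with no hydrogen-bond donor as well as either amide, and the three compounds stay within the scatter of one another. Nothing available explains this result.

As far as these compounds go, whether any group at this position can move the number beyond the scatter remains open, since all three compounds read alike. A carboxylic acid or an aminomethyl group on the same ring carbon, or the 1,2-oxazol-5-yl ring without its methyl, would test how far this tolerance extends.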